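Carbonyl side chain swap in the sulfonamide series

The source may report more compounds than this note shows. Statements on the series, on what has been measured and on what is new or still open speak of the compounds shown alone.

Measured in a physicochemical assay for solubility; a lower number here means a less soluble compound, a higher number a more soluble compound:
- compound 1 `O=C(O)c1ccc(S(=O)(=O)N2CCC(NS(=O)(=O)c3cc(S(=O)(=O)c4ccccc4)ccc3C(F)(F)F)CC2)cc1`: 12500 nM
- compound 2 `O=C(O)CCCC(=O)N1CCC(NS(=O)(=O)c2cc(S(=O)(=O)c3ccccc3)ccc2C(F)(F)F)CC1`: 50000 nM

Of these two compounds, the higher number belongs to compound 2, at 50000 nM, while compound 1 stands at 12500 nM. The next compound, compound 3 `O=C(C1CCNCC1)N1CCC(NS(=O)(=O)c2cc(S(=O)(=O)c3ccccc3)ccc2C(F)(F)F)CC1`, carries piperidin-4-yl in place of 3-carboxypropyl on a carbonyl carbon. The carbonyl itself and the rest of compound 2 stay as they are.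

Within the data shown here, only one measured step is available, a 4.0-fold higher number from compound 1 to compound 2 (0.60 log units; beyond the scatter). It is modest but beyond the scatter, and it concerns the group on the same amine nitrogen in a ring. Among the measured compounds shown here, it bears on the new change only indirectly, since no measured compound carries piperidin-4-yl and no measured step replaces 3-carboxypropyl. With that single step as a guide, a change no larger than it is expected in this assay, and the direction is uncertain, with a slightly lower number the more likely outcome. The expected step is a 1.7-fold lower number from compound 2 to compound 3 (0.22 log units; within the scatter). The estimate for compound 3 is 30000 nM, with an expected range from 10000 nM to 90000 nM.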

Compound 3, solubility: 100000 nM
For compound 3 the middle estimate is 3.3-fold (0.52 log units) below the measured one; the whole stated range lies below it.
By their numbers in this assay, from the lowest: compound 1; then compounds 2 and 3 (each within the scatter of the next).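

In this assay, the step from 3-carboxypropyl to piperidin-4-yl on the carbonyl carbon is small (a 2.0-fold higher number from compound 2 to compound 3 (0.30 log units; within the scatter)), so these two compounds cannot be told apart. This adds something the earlier pair could not show, since compounds 1 and 2 both carry a carboxy group and compound 3 carries none, yet a carboxy group is not needed for a number at the level of compound 2 in this series. The wider comparison is clearer, with (piperidin-4-yl)carbonyl in place of (4-carboxyphenyl)sulfonyl on the amine nitrogen giving an 8.0-fold higher number from compound 1 to compound 3 (0.90 log units; beyond the scatter), the largest step so far at this position, and no measurement shown here gives a reason for any of these differences.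

That largest step changes the sulfonyl to a carbonyl and replaces the group it carries, so 4-carboxybenzoyl on the same nitrogen would be needed to separate the two parts. On these data alone, whether the nitrogen in piperidin-4-yl matters remains open, and a cyclohexyl group on the same carbonyl carbon, set beside compound 3, would address that directly.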